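The compounds below may be only part of what the source reports. "The series", "measured", "known", "first", "only" and "open" are said of these compounds alone.

Compound 1 `Cc1ccccc1-c1nn(-c2ccc(Cl)cc2)cc1CNCCN1CCN(C)CC1` was examined in an ADME assay on Huh-7 cells (Homo sapiens) for cytotoxicity (on this read-out lower numbers stand for higher toxicity in this test and higher numbers for lower toxicity in this test), where compound 1 gives 17000 nM. Within the data shown here, of the two compounds measured so far, this is the higher number, so compound 1 is the less toxic of the pair. Compound 2 `CN1CCN(CCNCc2cn(-c3ccc([N+](=O)[O-])cc3)nc2-c2ccc(OC(F)(F)F)cc2)CC1` gives 4400 nM in this assay, a gap to compound 1 that lies beyond the usual scatter. Compound 2 differs from compound 1 in more than one place, so its value cannot be tied to any single change. Compound 3 `Cc1ccccc1-c1nn(-c2ccc(OC(F)(F)F)cc2)cc1CNCCN1CCN(C)CC1` keeps the core of compound 1 and differs in one spot only: trifluoromethoxy in place of chloro on an aromatic carbon. Among the measured compounds shown here, no measured pair isolates this change, so its direction is uncertain. A modest step toward a somewhat lower number is expected, a 1.7-fold lower number from compound 1 to compound 3 (0.23 log units; within the scatter). Compound 3 is therefore estimated at 10000 nM, with a range from 4000 nM to 25000 nM.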

Compound 3, half-maximal cytotoxic concentration: 17000 nM
Beside the measured number, compound 3's estimate is 1.7-fold (0.23 log units) below it, within the range that was stated.
By their numbers in this assay, from the lowest: compound 2; then compounds 1 and 3 (each within the scatter of the next).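

Within this assay the swap of chloro for trifluoromethoxy, on an aromatic carbon para to a large group, gives no change at the digits printed from compound 1 to compound 3 (within the scatter) and provides the first comparison here that isolates a single place. The entering group has 5 heavy atoms against 1 for chloro and adds a hydrogen-bond acceptor, yet this difference leaves the read-out within the usual scatter, so on this shared core the position accepts either group without a detectable shift in this test. Nothing available here explains why the two groups read alike. This is one pair on one core, so it does not show whether the same holds for other groups at this position. An amine, a carboxylic acid or a longer chain such as butoxy could give a quite different reading there.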